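Amine substituent survey in the bicyclic nucleoside series

The source may report more compounds than this note shows. Statements on the series, on what has been measured and on what is new or still open speak of the compounds shown alone.

Measured so far:
compound 1 `CCCCC#Cc1nc(NCc2cccc(Br)c2)c2ncn([C@H]3[C@H](O)[C@H](O)[C@@H]4C[C@@H]43)c2n1`, an assay on CHO cells for displacement of a labelled ligand from adenosine receptor A3 (Homo sapiens), with a stated time of 60 min (on this read-out higher numbers stand for weaker inhibition and lower numbers for stronger inhibition), 8.6 nM
compound 2 `CCCCC#Cc1nc(NCC)c2ncn([C@H]3[C@H](O)[C@H](O)[C@@H]4C[C@@H]43)c2n1`, 6.7 nM
compound 3 `CCCCC#Cc1nc(NC)c2ncn([C@H]3[C@H](O)[C@H](O)[C@@H]4C[C@@H]43)c2n1`, 4.9 nM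

Compound 3 shows the smallest number of the three, but the steps of a 1.8-fold lower number from compound 1 to compound 3 (0.24 log units; within the scatter) and a 1.4-fold lower number from compound 2 to compound 3 (0.14 log units; within the scatter) keep all three within a single band of scatter. Compound 4 `CCCCC#Cc1nc(NCc2cccc(F)c2)c2ncn([C@H]3[C@H](O)[C@H](O)[C@@H]4C[C@@H]43)c2n1` differs from compound 3 by 3-fluorophenyl in place of hydrogen on a saturated chain carbon bound to a nitrogen on an aromatic ring. For the measured compounds named here, the one measured step that bears on this change is a 1.8-fold lower number from compound 1 to compound 3 (0.24 log units; within the scatter), where a 3-bromophenyl group left the same carbon; reading that change in the opposite direction, with a 3-fluorophenyl group entering, the expectation in this assay is at most a small rise, not beyond scatter. Compound 4 is therefore expected near 8 nM, with a likely range of 3 nM to 20 nM. The expected step is a 1.6-fold higher number from compound 3 to compound 4 (0.21 log units; within the scatter).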

Compound 4, inhibition constant: 16 nM
Compound 4: the middle estimate sits 2.0-fold (0.30 log units) below what was measured; low and high end bracket the measured number.
By their numbers in this assay, from the lowest: compounds 3, 2, 1 and 4 (each within the scatter of the next, the first and the last beyond it).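

In this assay the change at this position now shows up beyond the scatter: 3-fluorophenyl in place of hydrogen (a 3.3-fold higher number from compound 3 to compound 4 (0.51 log units; beyond the scatter)) and in place of methyl (a 2.4-fold higher number from compound 2 to compound 4 (0.38 log units; beyond the scatter)) both raise the number. Fluoro in place of bromo on the aromatic carbon is not resolved (a 1.9-fold higher number from compound 1 to compound 4 (0.27 log units; within the scatter)), and compound 1 goes against any general benzyl penalty, staying within the scatter of compounds 2 and 3. No measured evidence accounts for the rise. Still open, from the compounds shown here alone, is how an unsubstituted benzyl or a 3-chlorobenzyl group would compare with compounds 1 and 4.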